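Varying the substituent on the chain carbon at the ring nitrogen

The compounds below may be only part of what the source reports. "The series", "measured", "known", "first", "only" and "open" are said of these compounds alone.

Measured compounds in a functional assay (trachea) with Cavia porcellus as the target; on this read-out higher numbers stand for weaker inhibition and lower numbers for stronger inhibition:
compound 1 `CCCn1nc(-c2cccnc2)c2ccccc2c1=O`, 3160 nM
compound 2 `O=c1c2ccccc2c(-c2cccnc2)nn1CC1CCCCC1`, 209 nM
compound 3 `CC(=O)OCCn1nc(-c2cccnc2)c2ccccc2c1=O`, 9770 nM

Compound 3 stands highest of the three numbers; compound 1 is nearest, compound 2 furthest, as the steps of a 3.1-fold higher number from compound 1 to compound 3 (0.49 log units; beyond the scatter) and a 47-fold higher number from compound 2 to compound 3 (1.67 log units; beyond the scatter) show. Compound 4 `O=C(O)c1ccc(Cn2nc(-c3cccnc3)c3ccccc3c2=O)cc1` is still unmeasured; it differs from compound 3 as follows: 4-carboxyphenyl in place of acetoxymethyl on a saturated chain carbon bound to an aromatic nitrogen.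

Among the compounds with values here, two steps bear on this change, both at the same chain carbon: a 15-fold lower number from compound 1 to compound 2 (1.18 log units; beyond the scatter) and a 47-fold higher number from compound 2 to compound 3 (1.67 log units; beyond the scatter). In each, the substituent carrying a ring gave the lower number, and the steps were large. Compound 4 brings a ring back at this position, so a lower number is expected, though no carboxylic acid has been measured here and the size is uncertain. For compound 4 the estimate is 1000 nM, range 200 nM to 5000 nM. The expected step is a 9.8-fold lower number from compound 3 to compound 4 (0.99 log units; beyond the scatter).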

Compound 4, half-maximal inhibitory concentration: 17000 nM
Compound 4: the middle estimate sits 17-fold (1.23 log units) below what was measured, outside the stated range (above it).
By their numbers in this assay, from the lowest: compound 2; then compound 1; then compounds 3 and 4 (each within the scatter of the next).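

A ring at this chain carbon does not by itself bring the lower number in this assay: 4-carboxyphenyl and acetoxymethyl stay within the scatter, a 1.7-fold higher number from compound 3 to compound 4 (0.24 log units; within the scatter), while replacing cyclohexyl with 4-carboxyphenyl gives an 81-fold higher number from compound 2 to compound 4 (1.91 log units; beyond the scatter). Ethyl also sits lower than 4-carboxyphenyl, a 5.4-fold higher number from compound 1 to compound 4 (0.73 log units; beyond the scatter), so cyclohexyl alone stands clear among the groups shown. No supporting data explain the gap between the two ring-bearing groups. Open, from the compounds shown here alone, is which part of 4-carboxyphenyl sets it apart from cyclohexyl. A plain phenyl without the carboxylic acid, or a cyclohexyl carrying one, at this chain carbon would separate the ring from the acid.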